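The compounds below may be only part of what the source reports. "The series", "measured", "known", "first", "only" and "open" are said of these compounds alone.

The compounds share one core, carrying its side chain attached in one way in compound 1 `O=C(COc1c(-c2ccccc2)oc2ccccc2c1=O)Nc1ccc2ccccc2c1` and in another in compound 2 `O=C(COc1ccc2c(=O)c(-c3ccccc3)coc2c1)Nc1ccc2ccccc2c1`. In a functional assay on NPC-TW01 cells (Homo sapiens) for antiproliferative activity, read by MTT assay, with a stated time of 72 h (a higher number here means a weaker inhibitor of growth, a lower number a stronger inhibitor of growth), compound 1 gives 6520 nM, and compound 2 gives 1370 nM. Compound 3 `O=C(COc1ccc2c(=O)c(-c3ccccc3)coc2c1)Nc1ccccc1` carries a plain phenyl on the amide-type nitrogen in place of the naphthalen-2-yl of compound 2. In this assay compound 3 gives only a limit of the assay, > 10000 nM, not a number. Within the data shown here, the step of an at least 7.2-fold higher number from compound 2 to compound 3 (0.86 log units; beyond the scatter) is the only step between measured compounds, and compound 3 stands at the limit of > 10000 nM in this assay, at which 1 of the 3 values shown sits.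

Compound 4 `O=C(COc1ccc2c(=O)c(-c3ccccc3)coc2c1)Nc1ccc(F)cc1` differs from compound 3 by fluoro in place of hydrogen on an aromatic carbon. Among the measured compounds shown here, none of the measured steps is of this kind: the one step that is known, an at least 7.2-fold higher number from compound 2 to compound 3 (0.86 log units; beyond the scatter), swaps a whole ring, whereas here a single fluorine replaces a hydrogen. Nothing among the three measured compounds shows how a fluoro on this ring shifts the read-out. The expectation for compound 4 is therefore no step beyond the scatter, a step that the limit leaves unreadable from compound 3 to compound 4, with the assay quite likely again reporting only a limit. The estimate for compound 4 in this assay is 12000 nM, in a range from 4000 nM to 35000 nM.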

Compound 4, concentration for 50% growth inhibition: 550 nM
The estimate for compound 4 lay 22-fold (1.34 log units) above the measured number, outside the stated range (below it).
By their numbers in this assay, from the lowest: compound 4; then compound 2; then compound 1. At a limit, above all of these: compound 3.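

The earlier compounds shown here showed only that a plain phenyl on the amide-type nitrogen does far worse than naphthalen-2-yl, which could have suggested that this position needs a large ring system. In this assay, the new result overturns that reading for these compounds: adding one fluoro to the phenyl ring, para to a large group, gives an at least 18-fold lower number from compound 3 to compound 4 (1.25 log units; beyond the scatter), and the 4-fluorophenyl group also outperforms naphthalen-2-yl, with a 2.5-fold lower number from compound 2 to compound 4 (0.40 log units; beyond the scatter). So a change of a single atom at this spot can matter more than the size of the ring, although the first of these steps is only a minimum, since compound 3 is reported as a limit of the assay and not as a number: the limit of > 10000 nM in this assay, at which 1 of the 4 values shown sits.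

The compounds shown leave open whether this gain is specific to fluoro or would also appear with chloro, methyl, methoxy or an amine at the same place on the ring. They also leave open whether the 4-fluorophenyl group would bring a similar gain with the side chain attached to the core as in compound 1.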